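This account rests on a few compounds, and the source may have more. Where it says the series, first, only, none or still open, it means among the compounds named here.

Compound 1 `CC(C)Oc1cccc2ccc(N)nc12` gives 437 nM in an assay on cells with melanin-concentrating hormone receptor 1 (Homo sapiens) as the target, read by radioligand binding; on this read-out lower numbers stand for stronger inhibition and higher numbers for weaker inhibition. Compound 2 `CCC#CCOc1cccc2ccc(N)nc12` reaches only the limit > 2000 nM in this assay, which is not a number.

Compound 1 thus stands as the only full number shown; the other value is a limit, as stated in the limit of > 2000 nM in this assay, at which 1 of the 2 values shown sits. The unmeasured compound 3 `CC(COC(C)(C)C)Oc1cccc2ccc(N)nc12` differs from compound 1 by tert-butoxy in place of hydrogen on a saturated chain carbon, two bonds along the chain from an oxygen on an aromatic ring, again enlarging the chain on the ether oxygen. For the measured compounds named here, the one measured step that bears on this is an at least 4.5-fold higher number from compound 1 to compound 2 (0.66 log units; beyond the scatter), where a longer chain in place of isopropyl moved the number out to the limit. Compound 3 carries a tert-butoxy addition rather than a longer linear chain, and for compound 3 the step is estimated as a weakening of a 3.0-fold higher number from compound 1 to compound 3 (0.47 log units; beyond the scatter). Compound 3 is therefore estimated at 1300 nM, within 450 nM to 3500 nM, with a real chance that only a limit is reported.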

Compound 3, half-maximal inhibitory concentration: 306 nM
For compound 3 the middle estimate is 4.2-fold (0.63 log units) above the measured one; measured number below the stated range.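

At the saturated chain carbon two bonds along the chain from an oxygen on an aromatic ring, tert-butoxy in place of hydrogen gives in this assay a 1.4-fold lower number from compound 1 to compound 3 (0.15 log units; within the scatter) and so no readable change. Enlarging the group on this oxygen therefore does not always go with a weaker number, and compound 3 shows this where compound 2 had suggested otherwise, with its pent-2-yn-1-yl giving an at least 4.5-fold higher number from compound 1 to compound 2 (0.66 log units; beyond the scatter) and its value being a limit rather than a number. Nothing given here accounts for the difference between these two changes.

As far as these compounds go, whether an amine or a carboxylic acid at this chain carbon would be tolerated as tert-butoxy is remains open. Also open, from the compounds shown here alone, is how a longer chain carrying tert-butoxy further out on the same oxygen would read.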